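This account rests on a few compounds, and the source may have more. Where it says the series, first, only, none or still open, it means among the compounds named here.

Compound 1, with the structure `CC(=O)/C(=N\Nc1ccccc1[N+](=O)[O-])N(C)c1cccc(Cl)c1`, is the starting point of this comparison. Among the measured compounds shown here, in an assay on isolated protein for binding affinity to corticotropin-releasing factor receptor 1 (Homo sapiens) (on this read-out higher numbers stand for weaker inhibition and lower numbers for stronger inhibition), compound 1 gives 8600 nM, and that is the only single number among the measured entries; the other compound comes with more than one entry. That other compound is compound 2, with the structure `CC(=O)/C(=N\Nc1ccccc1C(F)(F)F)Nc1cccc(Cl)c1`, and in this assay compound 2 gives 538 nM; 538 nM (2 entries). Compound 2 differs from compound 1 in two places at once, so the two values show only that they lie far apart, not which change carries the difference.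

Compound 3, with the structure `CC(=O)/C(=N\Nc1ccccc1Cl)N(C)c1cccc(Cl)c1`, is the compound to be measured next. It differs from compound 1 in one place only: chloro in place of nitro on an aromatic carbon. For the measured compounds named here, no measured pair shows this particular change by itself, so the size of its effect has to be guessed. The expectation is a step from compound 1 to compound 3 of a 2.9-fold lower number from compound 1 to compound 3 (0.46 log units; beyond the scatter), toward stronger binding, but of a size that could still fall within the usual scatter. Compound 3 is therefore expected to give about 3000 nM, somewhere between 800 nM and 12000 nM.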

Compound 3, inhibition constant: > 10000 nM
Compound 3: only a limit was reported; the forecaster's own chance of this, stated with the estimate: 10%; middle value at least 3.3-fold (0.52 log units) away from the limit.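

In this assay, compound 3 gives > 10000 nM, which is a limit of the assay and not a number. Placing chloro instead of nitro on this aromatic carbon, ortho to a large group, gives an at least 1.1-fold higher number from compound 1 to compound 3 (0.06 log units; that floor lies within the scatter), so the data show no gain in binding from this change and do not establish a loss either, as the floor of the step lies within the scatter. Among the compounds shown here, this is the first single-change comparison at this position, which the two earlier compounds could not provide, but it sets only a lower bound on the size of the step: the limit of > 10000 nM in this assay, at which 1 of the 3 values shown sits.

On these data alone, the true value of compound 3, and therefore the real size of this step, remains open, as does whether trifluoromethyl at this position or the second difference in compound 2 accounts for the gap between compound 1 and compound 2. As far as these compounds go, how a fluoro group, a nitrile or an amine would behave at this same position also remains unknown.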